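The compounds below may be only part of what the source reports. "The series", "measured", "known", "first", "only" and "open" are said of these compounds alone.

Two compounds from this series share a common core and were tested in a functional assay on ECa-109 cells (Homo sapiens) for inhibition, read by MTT assay, with a stated time of 72 h; on this read-out higher numbers stand for weaker inhibition and lower numbers for stronger inhibition. Compound 1 `COc1ccc(Nc2nc(SCc3cn(CC(=O)NC(=O)Nc4ccccn4)nn3)nc(-c3ccc(C(C)C)cc3)c2C#N)cc1` gives 5420 nM in this assay. Compound 2 `Cc1ccc(-c2nc(SCc3cn(CC(=O)NC(=O)Nc4ccccn4)nn3)nc(Nc3ccc(C(C)C)cc3)c2C#N)cc1` gives 7450 nM in this assay, which is the higher of the two numbers, though the gap to compound 1 lies within the scatter, so the two compounds cannot be ordered on these data.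

Compound 3 `COc1ccc(Nc2nc(SCc3cn(CC(=O)NC(=O)Nc4ccccn4)nn3)nc(-c3ccc(C)cc3)c2C#N)cc1` has not yet been measured. It follows from compound 2 by one change: methoxy in place of isopropyl on an aromatic carbon. Among the compounds with values here, no step between measured compounds isolates this swap, so the expectation rests on the closeness of compound 1 and compound 2 alone. The step of a 1.2-fold lower number from compound 2 to compound 3 (0.09 log units; within the scatter) is expected to be small, with no direction claimed beyond the scatter. Compound 3 is therefore estimated at 6000 nM in this assay, with a range from 2500 nM to 15000 nM.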

Compound 3, half-maximal inhibitory concentration: 5870 nM
For compound 3 the middle estimate is 1.0-fold (0.01 log units) above the measured one; the range from low to high includes it.
By their numbers in this assay, from the lowest: compounds 1, 3 and 2 (each within the scatter of the next).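

In this assay, compound 3 separates two swaps that compound 1 and compound 2 could only show together, since those two differ in more than one place. On the (4-isopropylphenyl)amino side, methoxy in place of isopropyl gives a 1.3-fold lower number from compound 2 to compound 3 (0.10 log units; within the scatter), while on the 4-isopropylphenyl side, methyl in place of isopropyl gives a 1.1-fold higher number from compound 1 to compound 3 (0.03 log units; within the scatter), so neither single swap moves the number beyond the scatter. No supporting measurement is available that bears on these results.

These three compounds cover only isopropyl, methoxy and methyl at these two places, so they do not show whether a group such as an amine, a carboxylic acid or a longer chain would leave the number equally unchanged. They also leave open whether methoxy and methyl can be exchanged on the same aromatic ring without a step beyond the scatter.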